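Swapping the para halogen: bromo to fluoro

The compounds below may be only part of what the source reports. "The series", "measured", "known", "first", "only" and "open" are said of these compounds alone.

Three compounds share a core in which an unsaturated thiol acid is attached to an aromatic ring. Compound 1 `O=C(O)/C(S)=C/c1ccccc1Cl` gives 20700 nM in an assay on isolated protein for inhibition of Calpain-1 catalytic subunit (Sus scrofa); on this read-out lower numbers stand for stronger inhibition and higher numbers for weaker inhibition. Compound 2 `O=C(O)/C(S)=C/c1ccc(Br)cc1` gives 1500 nM in this assay, which places it second highest of the three numbers; compound 3 `O=C(O)/C(S)=C/c1c[nH]c2c(I)cccc12` gives 220 nM in this assay, the lowest of the set.

Compound 4 `O=C(O)/C(S)=C/c1ccc(F)cc1` has not yet been measured. It differs from compound 2 by a single change, (fluoro in place of bromo on an aromatic carbon), fluoro in place of bromo on an aromatic carbon, para to a group of 6 heavy atoms. Within the data shown here, no step between measured compounds isolates this exchange, so what follows is an expectation only. Within this small set, the two halogen-bearing benzene compounds differ widely, and the lowest number comes from compound 3 with its iodo substituent; on that basis compound 4 is expected to give a higher number than compound 2, with an estimated step of a 3.3-fold higher number from compound 2 to compound 4 (0.52 log units; beyond the scatter) that lies beyond the scatter. Compound 4 is therefore estimated at 5000 nM in this assay, with a range from 1500 nM to 16000 nM.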

Compound 4, half-maximal inhibitory concentration: 5600 nM
Compound 4: the middle estimate sits 1.1-fold (0.05 log units) below what was measured; the measured number falls inside the stated range.
By their numbers in this assay, from the lowest: compound 3; then compound 2; then compound 4; then compound 1.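

In this assay fluoro in place of bromo on an aromatic carbon, para to a group of 6 heavy atoms, gives a 3.7-fold higher number from compound 2 to compound 4 (0.57 log units; beyond the scatter) with the rest of the structure unchanged. The earlier compounds shown here differ from one another in more than one place, so they could not show that this single halogen exchange alone moves the number beyond the scatter, with bromo carrying the lower number of the pair. Nothing given here accounts for the direction or size of this step.

The compounds shown leave open how a methoxy group, a nitrile or a plain hydrogen at this place would compare with bromo and fluoro. They also leave open whether the same kind of exchange would give a similar step elsewhere, as in place of the chloro of compound 1 or the iodo of compound 3.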